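A few compounds are considered here, and "the series" means these few. Any claim that something is new, unique, unknown or untested is made for them only; others in the source may bear on it.

For the measured compounds named here, in a functional assay on HEL cells (Homo sapiens) (a higher number here means that more compound is tolerated, a lower number that less compound is tolerated), compound 1 (`Cc1cn([C@@H]2O[C@H](CO[Si](C)(C)C(C)(C)C)[C@@]3(OS(=O)(=O)C=C3NCC(=O)C(=O)N3CCC3)[C@H]2O[Si](C)(C)C(C)(C)C)c(=O)n(C)c1=O`) gives 84400 nM and compound 2 (`Cc1cn([C@@H]2O[C@H](CO[Si](C)(C)C(C)(C)C)[C@@]3(OS(=O)(=O)C=C3NCCC(=O)O)[C@H]2O[Si](C)(C)C(C)(C)C)c(=O)n(C)c1=O`) gives 34000 nM, the lower of the two numbers so far. Compound 3 (`Cc1cn([C@@H]2O[C@H](CO[Si](C)(C)C(C)(C)C)[C@@]3(OS(=O)(=O)C=C3NCCC(=O)OCc3ccccc3)[C@H]2O[Si](C)(C)C(C)(C)C)c(=O)n(C)c1=O`) departs from compound 2 by benzyl in place of hydrogen on an oxygen next to a carbonyl group, which turns carboxy into benzyloxycarbonyl. Going by the values given here, only one measured step is available, a 2.5-fold lower number from compound 1 to compound 2 (0.39 log units; beyond the scatter). Among the compounds with values here, it changes the same chain but is a different replacement, and no measured step covers this oxygen. That modest step therefore sets only a rough scale for this assay. No clear direction can be drawn from it, so a change within the scatter is expected. The estimated step is a 1.1-fold lower number from compound 2 to compound 3 (0.05 log units; within the scatter). For compound 3 the expected value is 30000 nM, with an estimated range of 12000 nM to 80000 nM.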

Compound 3, half-maximal cytotoxic concentration: 200000 nM
Compound 3: middle estimate off by 6.7-fold (0.82 log units), on the low side, and the stated range ends below it.
By their numbers in this assay, from the lowest: compound 2; then compound 1; then compound 3.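

In this assay, for the compounds shown here, the oxygen next to the carbonyl group proves responsive to substitution: benzyl in place of hydrogen gives a 5.9-fold higher number from compound 2 to compound 3 (0.77 log units; beyond the scatter) and so runs opposite to the first step. The (benzyloxycarbonyl)methyl group also sits clear of ((azetidin-1-yl)carbonyl)carbonyl on the same chain carbon, with a 2.4-fold higher number from compound 1 to compound 3 (0.37 log units; beyond the scatter) on the shared core. No measurement on hand accounts for either step.

The compounds shown leave open whether the higher number belongs to benzyl itself or follows from any group on this oxygen, a question that a methyl group in place of benzyl would address. They also leave open how a longer chain carrying the carboxy group would read in this assay on this core.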